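The compounds below may be only part of what the source reports. "The series", "measured", "known", "first", "only" and "open" are said of these compounds alone.

In an ADME assay on Huh-7 cells (Homo sapiens) for cytotoxicity, read by MTT assay, with a stated time of 72 h (a lower number here means that less compound is tolerated, a higher number that more compound is tolerated), compound 1 `CONC(=O)c1ccccc1` gives > 800000 nM, which is a limit of the assay rather than a number. Compound 2 `CONC(=O)c1ccccc1O` likewise reaches only a limit, > 800000 nM. Compound 3 `Cc1ccccc1C(=O)NO` gives 650000 nM. Within the data shown here, compound 3 thus holds the only number among the three values; the other two sit at the limit of > 800000 nM in this assay, at which 2 of the 3 values shown sit. The step from compound 1 to compound 2, a step that the two limits leave unreadable from compound 1 to compound 2, cannot be read for size. Compound 4 `O=C(NO)c1ccccc1[N+](=O)[O-]` differs from compound 3 by nitro in place of methyl on an aromatic carbon. Among the measured compounds shown here, no measured step bears on this change, so no step beyond the scatter is expected in this assay: compound 4 is estimated at 700000 nM, within 300000 nM to 1500000 nM, an expected step of a 1.1-fold higher number from compound 3 to compound 4 (0.03 log units; within the scatter).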

Compound 4, half-maximal cytotoxic concentration: 55000 nM
For compound 4 the middle estimate is 13-fold (1.10 log units) above the measured one; the measured number lies below the stated range.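

At this place, on an aromatic carbon ortho to a group of 4 heavy atoms, nitro in place of methyl is not a neutral exchange in this assay: the change gives a 12-fold lower number from compound 3 to compound 4 (1.07 log units; beyond the scatter). Among these compounds, this is the first step here whose size can be read, and it shows that less compound is tolerated with nitro at this place. The earlier step cannot be read, as compounds 1 and 2 offer only a limit: the limit of > 800000 nM in this assay, at which 2 of the 4 values shown sit.

Going by these compounds, whether other groups at this place, such as an amine or a carboxylic acid, would read nearer compound 3 or compound 4 in this assay stays open. So does whether nitro has the same effect on the core of compound 1.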